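This account rests on a few compounds, and the source may have more. Where it says the series, first, only, none or still open, it means among the compounds named here.

Compound 1 `CC1CC(=O)N(CC(=O)N2CCN(c3ccccc3)CC2)C1=O` was examined in a functional assay on the whole organism (strain CD1) with Mus musculus as the target, in the maximal electroshock model, with a stated time of 0.5 h (on this read-out lower numbers stand for an effect already at smaller amounts and higher numbers for an effect only at larger amounts of compound), where compound 1 gives 300 mg/kg. Two measured relatives share its core. Compound 2 `Cc1ccccc1N1CCN(C(=O)CN2C(=O)CC(C)C2=O)CC1` gives 300 mg/kg in this assay, and compound 3 `CC1CC(=O)N(CC(=O)N2CCN(c3ccccc3F)CC2)C1=O` gives 300 mg/kg. On these numbers compound 1 stands level with both: the step of no change at the digits printed from compound 1 to compound 2 (within the scatter) and the step of no change at the digits printed from compound 1 to compound 3 (within the scatter) lie within the scatter, as does the step of no change at the digits printed from compound 2 to compound 3 (within the scatter). Compound 4 `CC1CC(=O)N(CC(=O)N2CCN(c3cccc(C(F)(F)F)c3)CC2)C1=O` has not been measured. It differs from compound 1 as follows: trifluoromethyl in place of hydrogen on an aromatic carbon. The measured steps bear on this: each of them also replaces a substituent on the same six-membered aromatic ring of carbon only. Neither no change at the digits printed from compound 1 to compound 2 (within the scatter) nor no change at the digits printed from compound 1 to compound 3 (within the scatter) moved the read-out beyond the scatter. A step of no size beyond the scatter is therefore expected in this assay, so that no change at the digits printed from compound 1 to compound 4 (within the scatter) is the estimated change. Compound 4 is expected to give about 300 mg/kg in this assay, within a range from 100 mg/kg to 600 mg/kg.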

Compound 4, minimum effective dose: 100 mg/kg
The estimate for compound 4 lay 3.0-fold (0.48 log units) above the measured number, within the range that was stated.
By their numbers in this assay, from the lowest: compound 4; then compounds 1, 2 and 3 (each within the scatter of the next).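

Trifluoromethyl in place of hydrogen gives a 3.0-fold lower number from compound 1 to compound 4 (0.48 log units; beyond the scatter) in this assay, so this ring of the shared core can move the read-out, which neither the methyl nor the fluoro change from compound 1 had shown. The effect is modest, but it shows that the flat values of compounds 1, 2 and 3 do not mean that every substitution on this ring is without consequence. Nothing given here accounts for the lower number of compound 4.

With only compound 4 carrying a group meta to a large group, the effect of trifluoromethyl itself cannot be separated from the effect of its place on the ring. From the compounds shown here alone, it also remains open whether chloro, methoxy or a nitrile at that place would lower the number as well.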